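The source may hold more compounds than are shown below. What is called first, only, known or untested is meant among the compounds shown, and "the series" means these compounds.

Series notes. Compound 1 `CCCSc1nnc(COc2cc(C)c3c(C)cc(=O)oc3c2)o1` and compound 2 `Cc1cc(OCc2nnc(SCc3cccc(F)c3)o2)cc2oc(=O)cc(C)c12` share one core and differ only in the group on the saturated chain carbon bound to sulfur. In a functional assay on MCF7 cells (Homo sapiens) for antiproliferative activity, read by MTT assay, with a stated time of 24 h (on this read-out lower numbers stand for stronger inhibition and higher numbers for weaker inhibition), compound 1 returns > 100000 nM, which is a limit of the assay and not a number, in line with the limit of > 100000 nM in this assay, at which 1 of the 2 values shown sits. In this assay, among the measured compounds shown here, compound 2 gives 26000 nM, the only plain number among the two values shown. The step of an at least 3.8-fold lower number from compound 1 to compound 2 (0.58 log units; beyond the scatter) is beyond the scatter.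

Compound 3 `Cc1cc(OCc2nnc(SCc3ccc(F)c(F)c3)o2)cc2oc(=O)cc(C)c12` is not yet measured. Against compound 2 the change is fluoro in place of hydrogen on an aromatic carbon. For the measured compounds named here, no measured step bears closely on this change: the single measured step, an at least 3.8-fold lower number from compound 1 to compound 2 (0.58 log units; beyond the scatter), exchanges an ethyl for a 3-fluorophenyl, a much larger change than one added fluoro on an aromatic carbon, and its size is known only as a lower bound. The added fluoro is therefore taken to leave the number roughly where compound 2 stands, with no step beyond the scatter in either direction. Compound 3 is expected near 20000 nM (range 7000 nM to 60000 nM), meaning an estimated step of a 1.3-fold lower number from compound 2 to compound 3 (0.11 log units; within the scatter).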

Compound 3, half-maximal inhibitory concentration: 33300 nM
Compound 3: middle estimate off by 1.7-fold (0.22 log units), on the low side; low and high end bracket the measured number.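

In this assay, among the compounds shown here, 3-fluorobenzyl to 3,4-difluorobenzyl gives a 1.3-fold higher number from compound 2 to compound 3 (0.11 log units; within the scatter), the first measured exchange on the aromatic part of this group; fluoro in place of hydrogen on this aromatic carbon, para to a large group and ortho to a fluoro group, does not separate the two compounds. The distance from the alkyl end of the series holds with the added fluoro, at an at least 3.0-fold lower number from compound 1 to compound 3 (0.47 log units; beyond the scatter), so both fluorinated benzyl compounds stand apart from compound 1. That distance has only a lower bound, since the value of compound 1 is a limit of the assay and not a number: the limit of > 100000 nM in this assay, at which 1 of the 3 values shown sits.

Open is whether this aromatic carbon responds to anything larger or different from fluoro, such as a methoxy group, a nitrile or an amine, since hydrogen and fluoro are the only two cases shown there. Open too, on these data alone, is how a plain benzyl group with no fluoro, or a longer chain such as phenethyl on the sulfur, would stand in this assay.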